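Thiourea to urea pair, benzyloxy swap on the shared core

The compounds below may be only part of what the source reports. "The series", "measured", "known", "first", "only" and "open" are said of these compounds alone.

Compound 1 `Cc1ccc(COc2ccc(C(=O)NC(=S)Nc3ccc(C)c(-c4nc5ccccc5[nH]4)c3)cc2)cc1` and compound 2 `Cc1ccc(NC(=S)NC(=O)c2ccc(OCc3cccc(F)c3)cc2)cc1-c1nc2ccccc2[nH]1` share a thiourea-linked core; compound 3 `Cc1ccc(COc2ccc(C(=O)NC(=O)Nc3ccc(C)c(-c4nc5ccccc5[nH]4)c3)cc2)cc1` and compound 4 `Cc1ccc(NC(=O)NC(=O)c2ccc(OCc3cccc(F)c3)cc2)cc1-c1nc2ccccc2[nH]1` carry the urea analogue, and the difference between the two cores is not broken down here. In a functional assay on SW-620 cells (Homo sapiens) for inhibition, read by MTT assay, with a stated time of 48 h (on this read-out lower numbers stand for stronger inhibition and higher numbers for weaker inhibition), compound 1 gives 60900 nM. Compound 2 reaches only the limit of this assay, > 100000 nM (the limit of > 100000 nM in this assay, at which 1 of the 3 values shown sits). Compound 3 gives 26000 nM in this assay, the lowest number recorded here. The change 3-fluorophenyl in place of 4-methylphenyl on a saturated chain carbon bound to an oxygen on an aromatic ring made an at least 1.6-fold higher number from compound 1 to compound 2 (0.21 log units; that floor lies within the scatter). The same change, (3-fluorophenyl in place of 4-methylphenyl on a saturated chain carbon bound to an oxygen on an aromatic ring), is now applied to compound 3. Since the earlier step from compound 1 to compound 2 weakened inhibition, compound 4 is expected to show a 1.9-fold higher number from compound 3 to compound 4 (0.28 log units; within the scatter) in this assay. Compound 4 is therefore estimated at 50000 nM, with a range from 25000 nM to 110000 nM.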

Compound 4, half-maximal inhibitory concentration: 39600 nM
Beside the measured number, compound 4's estimate is 1.3-fold (0.10 log units) above it, and the stated range covers the measured number.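

In this assay, 3-fluorophenyl in place of 4-methylphenyl on the urea core gives a 1.5-fold higher number from compound 3 to compound 4 (0.18 log units; within the scatter), so on this core the change produces no step beyond the scatter. Whether the change behaves alike on the two cores stays unresolved: the same change on two cores in this assay, an at least 1.6-fold higher number (0.21 log units; that floor lies within the scatter) from compound 1 to compound 2 and a 1.5-fold higher number (0.18 log units; within the scatter) from compound 3 to compound 4; the limit leaves it open whether they differ Compound 2 stands at a limit of the assay, > 100000 nM, so its step has only a floor, and these two steps show no transfer of a real effect from one core to the other.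

The four compounds leave open whether any group at this place moves the number beyond the scatter on either core. On these data alone, how an amine, a carboxylic acid or a longer chain in place of 3-fluorobenzyl would read remains open.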